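From pyridin-2-yl to pyridin-3-yl on the amide

This account rests on a few compounds, and the source may have more. Where it says the series, first, only, none or still open, it means among the compounds named here.

In a physicochemical assay for lipophilicity, read by HPLC, at pH 3.0 (a higher number here means a more lipophilic compound, a lower number a more polar compound), compound 2 (`CC(C)(C)c1cc(C(=O)Nc2ccccn2)n(Cc2ccccc2)n1`) reads 4.5 and stands highest of the three numbers in hand. Compound 1 (`CC(C)(C)c1cc(C(=O)Nc2nc(CNS(C)(=O)=O)cs2)n(Cc2ccccc2)n1`) reads 3.7 and is the nearest, lower by more than the scatter. Compound 3 (`NCc1csc(NC(=O)c2ccn[nH]2)n1`) reads 0 and is the furthest, again beyond the scatter.

Compound 4 (`CC(C)(C)c1cc(C(=O)Nc2cccnc2)n(Cc2ccccc2)n1`) keeps the atoms of compound 2 but joins them differently, and the change is pyridin-3-yl in place of pyridin-2-yl on an amide-type nitrogen with pyridin-3-yl in place of pyridin-2-yl on an amide-type nitrogen. Among the measured compounds shown here, no measured pair shows this change, so the size of the step remains a judgement and not a reading. A fall in this assay beyond the scatter is expected, although a smaller move cannot be ruled out. The estimated step is a number 0.90 log units lower from compound 2 to compound 4 (beyond the scatter) in that downward direction. For compound 4 the estimate is 3.6 with an expected range from 2.7 to 4.4 as the working figures for now.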

Compound 4, distribution coefficient: 3.5
Beside the measured number, compound 4's estimate is 0.10 log units above it, within the range that was stated.
By their numbers in this assay, from the lowest: compound 3; then compounds 4 and 1 (each within the scatter of the next); then compound 2.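

Among the compounds shown here, this is the first pair that differs in one place, and in this assay it gives a number 1.00 log units lower from compound 2 to compound 4 (beyond the scatter). Pyridin-3-yl in place of pyridin-2-yl on an amide-type nitrogen therefore moves the reading beyond the scatter, even though both groups have the same heavy-atom, donor and acceptor counts. Nothing measured here bears on what lies behind this step.

Going by these compounds, it remains open how a phenyl group on the same amide-type nitrogen, or a pyridin-3-yl group carrying an amine or a carboxylic acid, would read in this assay. Also open, on these data alone, is whether the same change gives a step of similar size on a different core, as this single pair cannot show whether the step carries over.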